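The compounds below may be only part of what the source reports. "The series", "measured", "known", "first", "only" and "open" are said of these compounds alone.

Measured compounds:
- compound 1 `CCCCc1nc(=O)c(S(=O)(=O)c2ccc(-c3cccnc3)cc2)c(O)n1-c1c(OC)cccc1OC`: 88%
- compound 2 `CCCCc1nc(=O)c(S(=O)(=O)c2ccc(-n3ccccc3=O)cc2)c(O)n1-c1c(OC)cccc1OC`: 87%

Within the data shown here, in an ADME assay on microsomes from liver (Homo sapiens) for metabolic stability, using NADPH, with a stated time of 10 min (a lower number here means that less of the compound is left, a higher number that more of the compound is left), compound 1 gives 88% and compound 2 gives 87%; the two stand within the scatter of each other, the only step being a number 1 percentage points lower from compound 1 to compound 2 (within the scatter). Compound 3 `CCCCc1nc(=O)c(S(=O)(=O)c2ccc(-n3cc(Cl)ccc3=O)cc2)c(O)n1-c1c(OC)cccc1OC` differs from compound 2 by chloro in place of hydrogen on an aromatic carbon. Among the measured compounds shown here, no measured step touches that position. Compound 3 is therefore expected to stay in the same high region as compound 2, with a step of a number 2 percentage points lower from compound 2 to compound 3 (within the scatter) in this assay, no change beyond the scatter expected. The estimate for compound 3 is 85%, between 70% and 96%.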

Compound 3, percent of the compound remaining: 94%
For compound 3 the middle estimate is 9 percentage points below the measured one; measured number inside the range.
By their numbers in this assay, from the lowest: compounds 2, 1 and 3 (each within the scatter of the next).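

In this assay, chloro in place of hydrogen on an aromatic carbon, two atoms from the ring nitrogen, gives a number 7 percentage points higher from compound 2 to compound 3 (within the scatter), so this position accepts chloro with no change that stands out from the scatter. Set against the group carried by compound 1, the chloro-bearing group gives a number 6 percentage points higher from compound 1 to compound 3 (within the scatter), again without a change beyond the scatter. No available evidence bears on either step.

As far as these compounds go, whether a methyl, a methoxy or an amine at this position would keep the number in the same region remains open. So does whether chloro elsewhere on this ring would do the same.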